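Chlorophenyl in place of nitrophenol in a chalcone sulfonylurea

The compounds below may be only part of what the source reports. "The series", "measured", "known", "first", "only" and "open" are said of these compounds alone.

Measured so far in an ADME assay on the whole organism for cytotoxicity, with Artemia salina as the target, with a stated time of 24 h; on this read-out higher numbers stand for an effect only at larger amounts of compound and lower numbers for an effect already at smaller amounts:
Compound 1 `Cc1ccc(S(=O)(=O)NC(=O)Nc2ccccc2C(=O)/C=C/c2cccc(O)c2)cc1` gives 39.3 ug/mL.
Compound 2 `Cc1ccc(S(=O)(=O)NC(=O)Nc2ccccc2C(=O)/C=C/c2cc(O)ccc2[N+](=O)[O-])cc1` gives 18.3 ug/mL.

For the measured compounds named here, compound 2 holds the lowest of the two numbers in this assay, and its only neighbour is compound 1, which sits a modest and scatter-exceeding distance above it. Going by the values given here, the single measured step is a 2.1-fold lower number from compound 1 to compound 2 (0.33 log units; beyond the scatter), which brought the number down when a nitro entered.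

Compound 3 `Cc1ccc(S(=O)(=O)NC(=O)Nc2ccccc2C(=O)/C=C/c2ccccc2Cl)cc1` has not yet been measured. It differs from compound 2 by 2-chlorophenyl in place of 5-hydroxy-2-nitrophenyl on a double-bonded chain carbon bound to a double-bonded chain carbon. The measured step bears on this change only in part: the nitro that entered in a 2.1-fold lower number from compound 1 to compound 2 (0.33 log units; beyond the scatter) leaves again here, which on its own would point back up toward compound 1. Among the compounds with values here, for the hydroxy that leaves and the chlorine that enters no measured step exists, so the net outcome is uncertain.

Compound 3 is therefore expected to give a number close to that of compound 1, with the step of a 1.9-fold higher number from compound 2 to compound 3 (0.28 log units; within the scatter), estimated at 35 ug/mL, within a range of 12 ug/mL to 100 ug/mL.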

Compound 3, concentration for half-maximal effect: 12.8 ug/mL
The estimate for compound 3 lay 2.7-fold (0.44 log units) above the measured number; the range from low to high includes it.
By their numbers in this assay, from the lowest: compounds 3 and 2 (each within the scatter of the next); then compound 1.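

In this assay, replacing 5-hydroxy-2-nitrophenyl with 2-chlorophenyl on a double-bonded chain carbon bound to a double-bonded chain carbon gives a 1.4-fold lower number from compound 2 to compound 3 (0.16 log units; within the scatter), so the loss of the nitro did not carry the number back toward compound 1. The same place takes 2-chlorophenyl in place of 3-hydroxyphenyl with a 3.1-fold lower number from compound 1 to compound 3 (0.49 log units; beyond the scatter), which shows that a number well apart from compound 1 does not require a nitro or a hydroxy on this ring, since 2-chlorophenyl has neither and counts no hydrogen-bond donors or acceptors. Two quite different groups, one of 10 heavy atoms and one of 7, thus give numbers that cannot be told apart here, and nothing measured on these compounds explains this result.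

On these data alone, it stays open whether the chlorine itself matters, as the three compounds offer no plain phenyl to set against 2-chlorophenyl at this place. As far as these compounds go, what a phenyl carrying an amine or a carboxylic acid would give in this assay also remains unknown, as does whether the chlorine would act the same way elsewhere on the ring.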